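This account rests on a few compounds, and the source may have more. Where it says the series, first, only, none or still open, it means among the compounds named here.

Values in a functional assay on HL-60 cells (Homo sapiens) for inhibition, read by MTT assay, with a stated time of 72 h, tested at 30 uM (on this read-out higher numbers stand for more inhibition of growth at the one concentration tested and lower numbers for less inhibition of growth), for the measured members of the series:

compound 1 `C=CCc1ccc(OCc2cn(-c3ccccc3CO)nn2)c(O)c1`: 31.7%
compound 2 `C=CCc1ccc(OCc2cn(-c3ccccc3Cl)nn2)c(O)c1`: 38.7%
compound 3 `C=CCc1ccc(OCc2cn(-c3ccc(C(=O)c4ccccc4)cc3)nn2)c(O)c1`: 38.3%

On the numbers shown, compound 3 sits in the middle of the three, and all three values lie within the scatter of one another, so no member of the measured set can be set apart from the others on this read-out. Within the data shown here, the only single-point step among the measured compounds is a number 7 percentage points higher from compound 1 to compound 2 (within the scatter), which exchanges one substituent for another on the aryl group attached to the triazole and leaves the read-out essentially unchanged.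

Compound 4 `C=CCc1ccc(OCc2cn(-c3ccc(OC)cc3)nn2)c(O)c1` differs from compound 3 in one place: methoxy in place of benzoyl on an aromatic carbon. This is again an exchange of a substituent on the same aryl group, the kind of change that the step from compound 1 to compound 2 left within the scatter. The three measured values together suggest that this aryl substituent has so far not moved growth inhibition by any amount that can be resolved.

Compound 4 is therefore expected to give a value close to that of compound 3, with a step of a number 2.3 percentage points lower from compound 3 to compound 4 (within the scatter) that is not expected to exceed the scatter. The estimate for compound 4 in this assay is 36%, with a range from 24% to 48%.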

Compound 4, percent growth inhibition at one concentration: 21.3%
Estimate against measurement, compound 4: 14.7 percentage points above; the whole stated range lies above it.
By their numbers in this assay, from the lowest: compound 4; then compounds 1, 3 and 2 (each within the scatter of the next).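

In this assay, the aryl substituent on an aromatic carbon, para to a large group, proves able to move the read-out: methoxy in place of benzoyl gives a number 17 percentage points lower from compound 3 to compound 4 (beyond the scatter), although the count of hydrogen-bond acceptors stays the same and the change removes a six-membered aromatic ring and most of the heavy atoms of the substituent. The 4-methoxyphenyl group also stands apart from the two other aryl groups, with a number 17.4 percentage points lower from compound 2 to compound 4 (beyond the scatter) against 2-chlorophenyl and a number 10.4 percentage points lower from compound 1 to compound 4 (beyond the scatter) against 2-(hydroxymethyl)phenyl, which makes compound 4 the least active of the four at the one concentration tested. The earlier picture of an aryl substituent with no resolvable effect therefore holds only among compound 1, compound 2 and compound 3, and the steps to compound 4 are modest.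

Nothing in hand accounts for the lower number of compound 4. Going by these compounds, it remains open whether the drop follows from the methoxy group itself or from the loss of benzoyl, and an amine, a carboxylic acid or a longer alkoxy chain on the same aromatic carbon would help to separate the two.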